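Dropping the chloro from compound 1 to reach compound 4

The compounds below may be only part of what the source reports. "The series", "measured", "known", "first", "only" and "open" are said of these compounds alone.

Measured compounds:
compound 1, `Cn1c(-c2cccc(Cl)c2)nc2c(NC3CCCC3)ncnc21`: 514 nM
compound 2, `Cn1c(-c2ccc(C(=O)O)cc2)nc2c(NC3CCCC3)ncnc21`: 25700 nM
compound 3, `Cn1c(-c2ccccc2)nc2c(NC3CCOC3)ncnc21`: 6260 nM

In an assay on CHO cells for displacement of a labelled ligand from adenosine receptor A3 (Homo sapiens), read by scintillation counting, with a stated time of 3 h (a lower number here means a stronger inhibitor, a higher number a weaker inhibitor), compound 1 gives 514 nM, the lowest of the three numbers and therefore the strongest inhibitor of the set. The nearest of the others is compound 3, which in this assay gives 6260 nM, a gap well beyond the scatter; compound 2 lies furthest away with 25700 nM in this assay. Compounds 2 and 3 each differ from compound 1 in more than one place, so those gaps cannot be assigned to a single change.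

Compound 4, `Cn1c(-c2ccccc2)nc2c(NC3CCCC3)ncnc21`, has not yet been measured. It differs from compound 1 in one place only: hydrogen in place of chloro on an aromatic carbon. Put another way, the 3-chlorophenyl group of compound 1 becomes a plain phenyl group in compound 4, the hydrogen now standing meta to a large group.

Going by the values given here, no single-change step between measured compounds is available to calibrate this, so the expectation rests on compound 1 alone. Compound 4 is expected to be a somewhat weaker inhibitor than compound 1, with a step of a 2.9-fold higher number from compound 1 to compound 4 (0.47 log units; beyond the scatter) that may sit just beyond the scatter. The estimate for compound 4 in this assay is 1500 nM, ranging from 450 nM to 5000 nM.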

Compound 4, inhibition constant: 846 nM
The estimate for compound 4 lay 1.8-fold (0.25 log units) above the measured number; the range from low to high includes it.
By their numbers in this assay, from the lowest: compounds 1 and 4 (each within the scatter of the next); then compound 3; then compound 2.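

In this assay, the exchange of 3-chlorophenyl for phenyl gives a 1.6-fold higher number from compound 1 to compound 4 (0.22 log units; within the scatter) and so stays inside the usual scatter, which means that the chloro on this aromatic carbon is not shown to matter for this pair. The carboxy group is a different case: hydrogen in its place on an aromatic carbon gives a 30-fold lower number from compound 2 to compound 4 (1.48 log units; beyond the scatter) and is the largest of the new steps, so what stands on the phenyl group can count for a great deal even though the chloro does not. On the nitrogen on the aromatic ring, cyclopentyl in place of oxolan-3-yl gives a 7.4-fold lower number from compound 3 to compound 4 (0.87 log units; beyond the scatter), a modest step beyond the scatter, which shows that this group also matters on a plain phenyl background.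

On these data alone, whether a methoxy group, an amine or a fluoro on the phenyl group would track the chloro or the carboxy remains open, as does the outcome of a cyclohexyl group or a longer chain on that nitrogen. Nothing available explains any of these steps.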